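The source may hold more compounds than are shown below. What is called first, only, known or untested is meant among the compounds shown, and "the series" means these compounds.

Working notes on the series. The shared core carries a urea-linked 3-methylphenyl group in compound 1 `Cc1ccc([C@@H]2C[C@H](c3ccccc3)N(CC(=O)NC(C)(C)C)C(=O)[C@H](NC(=O)Nc3cccc(C)c3)C2)cc1`, compound 2 `Cc1cccc(NC(=O)N[C@@H]2C[C@H](c3ccccc3C)C[C@H](c3ccccc3)N(CC(=O)NC(C)(C)C)C2=O)c1` and compound 3 `Cc1cccc(NC(=O)N[C@@H]2C[C@H](c3ccccc3C)C[C@H](c3ccccc3)N(CC(=O)NC3(C)CCCCC3)C2=O)c1`. In an assay on isolated protein for inhibition of Cholecystokinin receptor type A (Cavia porcellus) (on this read-out lower numbers stand for stronger inhibition and higher numbers for weaker inhibition), compound 1 gives 1.1 nM. Compound 2 has several entries in this assay, 610 nM; 580 nM; 930 nM (3 entries), and stands well apart from the other two; the spread of these entries is given by the several entries of compound 2 in this assay, 610 nM; 580 nM; 930 nM (3 entries). Compound 3 gives 4.4 nM in this assay, which is the higher of the two single numbers, above compound 1 by more than the usual scatter, while compound 2 contributes no single number for comparison.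

Compound 4 `CCc1cccc(NC(=O)N[C@@H]2C[C@H](c3ccccc3C)C[C@H](c3ccccc3)N(CC(=O)NC3(C)CCCCC3)C2=O)c1` has not been measured in this assay. It differs from compound 3 by methyl in place of hydrogen on a saturated chain carbon bound to an aromatic carbon. Among the compounds with values here, no measured pair shows this change, so its effect has to be taken as an expectation only. The change is small, confined to the group on the urea nitrogen, and with nothing in the series to point either way the step from compound 3 to compound 4 is expected to be a 1.1-fold higher number from compound 3 to compound 4 (0.06 log units; within the scatter), that is, no change beyond the scatter. Compound 4 is therefore estimated at 5 nM in this assay, within a range from 1.5 nM to 16 nM.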

Compound 4, half-maximal inhibitory concentration: > 10 nM
Compound 4 gave a limit, no number; the forecaster's own chance of this, stated with the estimate: 2%; at least 2.0-fold (0.30 log units) between middle value and limit.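

In this assay compound 4 returns > 10 nM, which is a limit of the assay and not a number. Even so, the single added methyl on a saturated chain carbon bound to an aromatic carbon, which turns 3-methylphenyl into 3-ethylphenyl, gives an at least 2.2-fold higher number from compound 3 to compound 4 (0.35 log units; beyond the scatter), the first view of this place in the series, since all the earlier compounds carry the same 3-methylphenyl group and so gave no reading of it. The step marks only the smallest size the change can have, and its upper end stays undefined: the limit of > 10 nM in this assay, at which 1 of the 4 values shown sits.

Open, going by these compounds, is how the read-out runs with a longer chain such as propyl in place of the ethyl, or with a different group there such as methoxy or chlorine, and whether any such group would return a number rather than a limit. Also open, on these data alone, is whether the methyl to ethyl change acts the same way on the core of compound 1 or alongside the tert-butyl amide of compound 2.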